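A few compounds are considered here, and "the series" means these few. Any claim that something is new, unique, unknown or untested is made for them only; others in the source may bear on it.

Working notes on the series. Compound 1 `O=C1O[C@@H](CN2CCC(O)CC2)CN1c1ccc(-n2cc(-c3ccccn3)cn2)c(F)c1` and compound 2 `O=C1O[C@@H](CSc2cccs2)CN1c1ccc(-n2cc(-c3ccccn3)cn2)c(F)c1` share one core and differ only in the side group. In an ADME assay on L02 cells (Homo sapiens) for cytotoxicity, read by MTT assay, with a stated time of 48 h (on this read-out higher numbers stand for weaker inhibition and lower numbers for stronger inhibition), compound 1 gives only a limit, > 400 ug/mL. In this assay compound 2 likewise gives only a limit, > 400 ug/mL. Within the data shown here, the single measured step, a step that the two limits leave unreadable from compound 1 to compound 2, therefore has no readable size. The whole of the evidence is the limit of > 400 ug/mL in this assay, at which 2 of the 2 values shown sit. Compound 2 thus stands at the edge of the numbers shown, with no true number anywhere in the series to place it against.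

Compound 3 `O=C1O[C@@H](CNC(=O)C(F)(F)F)CN1c1ccc(-n2cc(-c3ccccn3)cn2)c(F)c1` is the next member. Its change from compound 2 is ((trifluoromethyl)carbonyl)amino in place of (thiophen-2-yl)sulfanyl on a saturated chain carbon bound to a saturated ring carbon. Among the measured compounds shown here, the one measured step bears on this exchange only as a limit: the step from compound 1 to compound 2 gives no size, so nothing here reads in either direction, and no step beyond the scatter is indicated. The expectation for compound 3 in this assay is that the step of a number no higher from compound 2 to compound 3 (the limit leaves the size open) again stays unreadable, with the value at the limit. Compound 3 is accordingly estimated at 400 ug/mL, in a range from 150 ug/mL to 800 ug/mL.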

Compound 3, half-maximal inhibitory concentration: > 400 ug/mL
Compound 3 was reported as a limit; the forecaster's own chance of this, stated with the estimate: 85%; the middle value lies on the limit itself.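

In this assay compound 3 gives > 400 ug/mL, again a limit of the assay and not a number. Among these compounds, no step among compound 1, compound 2 and compound 3 can therefore be read. The compounds shown leave open whether any of these side-group exchanges alters the read-out, and what true value any compound has: the limit of > 400 ug/mL in this assay, at which 3 of the 3 values shown sit.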